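The source may hold more compounds than are shown below. What is called first, only, known or untested is meant among the compounds shown, and "the series" means these compounds.

Working notes on the sulfonate ester series.

Compound 1 `CCOS(=O)(=O)/C=C/c1ccc(OCc2ccccc2)cc1OCCc1nc(-c2ccccc2)oc1C` carries the oxazole side chain on the shared core. In an ADME assay on COS-7 cells (Chlorocebus aethiops) for cytotoxicity, read by MTT assay, with a stated time of 48 h (on this read-out higher numbers stand for weaker inhibition and lower numbers for stronger inhibition), compound 1 gives > 100000 nM, which is a limit of the assay rather than a number. Compound 2 `CCOS(=O)(=O)/C=C/c1ccc(OCc2ccccc2)cc1OCCc1nc(-c2ccccc2)sc1C` replaces the oxazole with the thiazole. In this assay compound 2 gives > 100000 nM, again a limit. The step that the two limits leave unreadable from compound 1 to compound 2 is therefore not readable. Compound 3 `CCOS(=O)(=O)/C=C/c1ccc(OCc2cc(-c3ccccc3)on2)cc1` carries a different side chain altogether. In this assay compound 3 gives > 100000 nM, also a limit. Among the measured compounds shown here, the whole set is summarised by the limit of > 100000 nM in this assay, at which 3 of the 3 values shown sit, so no measured step gives a readable size.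

Compound 4 `CCCCOS(=O)(=O)/C=C/c1ccc(OCc2ccccc2)cc1OCCc1nc(-c2ccccc2)oc1C` is the next member. The change from compound 1 is ethyl in place of hydrogen on a saturated chain carbon, two bonds along the chain from an oxygen on an unsaturated carbon, in words: ethyl in place of hydrogen on a saturated chain carbon, two bonds along the chain from an oxygen on an unsaturated carbon. For the measured compounds named here, no measured step bears on this change, and the one step in hand is unreadable. With every value sitting at the limit, the expectation is a step of no readable size, and the expected step that the limit leaves unreadable from compound 1 to compound 4 means no shift beyond the scatter. Compound 4 is expected to give 150000 nM, with a range of 60000 nM to 500000 nM, most likely reported again as a limit.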

Compound 4, half-maximal inhibitory concentration: > 100000 nM
Compound 4: only a limit was reported; the forecaster's own chance of this, stated with the estimate: 85%; the middle value lies beyond the limit too.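

In this assay compound 4 gives > 100000 nM, a limit and not a number, so the step from compound 1 to compound 4 cannot be read. The compounds shown leave open whether any change on the shared core moves this read-out at all: the limit of > 100000 nM in this assay, at which 4 of the 4 values shown sit.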